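Rearranging the aryl substituents in a dicarboxylic amidine series

This account rests on a few compounds, and the source may have more. Where it says the series, first, only, none or still open, it means among the compounds named here.

Measured compounds:
compound 1, `CCCCC(NC(=O)C(CC(=O)O)NC(=O)CCCOc1ccc(C(=N)N)cc1)C(=O)O`, 1.58;
compound 2, `CC(C)(C)CC(NC(=O)C(CC(=O)O)NC(=O)CCCOc1ccc(C(=N)N)cc1)C(=O)O`, 1.59;
compound 3, `CCc1ccc(OCCNC(=O)C(CC(=O)O)NC(=O)CCCOc2ccc(C(=N)N)cc2)cc1`, 1.95.

Compound 3 stands highest of the three values in a physicochemical assay for lipophilicity (a higher number here means a more lipophilic compound, a lower number a more polar compound), its nearest neighbour being compound 2 and the furthest compound 1, both gaps lying beyond the scatter. The two steps that lead to compound 3 are of similar size: a number 0.37 log units higher from compound 1 to compound 3 (beyond the scatter) and a number 0.36 log units higher from compound 2 to compound 3 (beyond the scatter). The step of a number 0.01 log units higher from compound 1 to compound 2 (within the scatter) shows that reshaping a saturated chain while keeping its size did not move the number.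

Compound 4, `Cc1ccc(OCCNC(=O)C(CC(=O)O)NC(=O)CCCOc2ccc(C(=N)N)cc2)cc1C`, differs from compound 3 in one place: 3,4-dimethylphenyl in place of 4-ethylphenyl on an oxygen on a saturated carbon. The two compounds have the same atoms, joined differently, with the same ring, the same donor and acceptor count and no change in charge. For the measured compounds named here, no measured step alters a substituent pattern on this aromatic ring, so nothing bears on the change directly; the closest point of comparison is the step from compound 1 to compound 2, a rearrangement of saturated carbons that stayed within the scatter. By that analogy compound 4 is expected to show no change at the digits printed from compound 3 to compound 4 (within the scatter), a step that stays within the scatter in this assay. The estimate for compound 4 is therefore 1.95, with a range from 1.65 to 2.25.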

Compound 4, partition coefficient: 1.43
Beside the measured number, compound 4's estimate is 0.52 log units above it, outside the stated range (below it).
By their numbers in this assay, from the lowest: compounds 4, 1 and 2 (each within the scatter of the next); then compound 3.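

In this assay, the aryl group on this oxygen turns out to matter even with its atoms conserved: 3,4-dimethylphenyl in place of 4-ethylphenyl gives a number 0.52 log units lower from compound 3 to compound 4 (beyond the scatter), whereas the rearrangement of saturated carbons gave a number 0.01 log units higher from compound 1 to compound 2 (within the scatter). The 2-(4-ethylphenoxy)ethyl group had set compound 3 apart from the two compounds with saturated carboxylic chains, but its 3,4-dimethylphenoxy counterpart does not, with a number 0.16 log units lower from compound 2 to compound 4 (within the scatter) and a number 0.15 log units lower from compound 1 to compound 4 (within the scatter), so an aryloxyethyl group on the amide-type nitrogen does not by itself separate a compound from that pair. Nothing available accounts for the difference between the two aromatic substitution patterns.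

The compounds shown leave open whether the result follows the loss of the 4-ethyl group or the presence of the two methyl groups, a question that a 4-methylphenyl or 3-ethylphenyl group on the same oxygen could help to separate. They also leave open whether a 4-propylphenyl group would continue the value of compound 3 1.95 or fall back towards that of compound 4 1.43.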